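This account rests on a few compounds, and the source may have more. Where it says the series, first, only, none or still open, it means among the compounds named here.

The three measured compounds share one core and differ only in the group on one aromatic carbon. Compound 1 `CCOC(=O)c1cnc(SC)nc1NN1C(=O)C=C(C)C1=O` carries a methylsulfanyl group there; in a functional assay on Jurkat cells for inhibition of nuclear factor NF-kappa-B complex (Homo sapiens) (a lower number here means a stronger inhibitor, a higher number a weaker inhibitor), compound 1 gives 200 nM. Compound 2 `CCOC(=O)c1cnc(-c2csc(C)n2)nc1NN1C(=O)C=C(C)C1=O` carries a 2-methyl-1,3-thiazol-4-yl group, and in this assay compound 2 gives 8000 nM. Compound 3 `CCOC(=O)c1cnc(-c2cccc(OC)c2)nc1NN1C(=O)C=C(C)C1=O` carries a 3-methoxyphenyl group, and in this assay compound 3 gives 5000 nM. Compound 2 thus holds the highest of the three numbers: a 40-fold higher number from compound 1 to compound 2 (1.60 log units; beyond the scatter), and a 1.6-fold lower number from compound 2 to compound 3 (0.20 log units; within the scatter).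

Compound 4 `CCOC(=O)c1cnc(-c2ccc(Cl)s2)nc1NN1C(=O)C=C(C)C1=O` has not yet been measured. Its difference from compound 2 is 5-chlorothiophen-2-yl in place of 2-methyl-1,3-thiazol-4-yl on an aromatic carbon. Of the measured steps, a 40-fold higher number from compound 1 to compound 2 (1.60 log units; beyond the scatter) and a 25-fold higher number from compound 1 to compound 3 (1.40 log units; beyond the scatter) both describe the exchange of methylsulfanyl for an aromatic group, so they do not bear directly on the exchange of one aromatic group for another; the step that does, a 1.6-fold lower number from compound 2 to compound 3 (0.20 log units; within the scatter), stayed within the scatter. For compound 4 the account therefore expects no step beyond the scatter in this assay, which amounts to an estimated 1.1-fold lower number from compound 2 to compound 4 (0.06 log units; within the scatter). Compound 4 is expected to give about 7000 nM in this assay, within a range from 2000 nM to 25000 nM.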

Compound 4, half-maximal inhibitory concentration: 300 nM
Compound 4: the middle estimate sits 23-fold (1.37 log units) above what was measured; the measured number lies below the stated range.
By their numbers in this assay, from the lowest: compounds 1 and 4 (each within the scatter of the next); then compounds 3 and 2 (each within the scatter of the next).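

In this assay, the exchange of one aromatic group for another at this position, on the aromatic carbon between two ring nitrogen atoms, proves far from neutral: 5-chlorothiophen-2-yl gives a much stronger inhibitor than either 2-methyl-1,3-thiazol-4-yl (a 27-fold lower number from compound 2 to compound 4 (1.43 log units; beyond the scatter)) or 3-methoxyphenyl (a 17-fold lower number from compound 3 to compound 4 (1.22 log units; beyond the scatter)). The large losses seen on leaving methylsulfanyl are therefore not general to aromatic groups here, for the step to 5-chlorothiophen-2-yl stays within the scatter (a 1.5-fold higher number from compound 1 to compound 4 (0.18 log units; within the scatter)), and compound 4 goes against any such rule. The two five-membered aromatic rings of compound 2 and compound 4 carry the same count of heavy atoms, so that count does not separate them, and nothing shown accounts for the gap between them.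

The compounds shown do not tell whether the chlorine or the thiophene ring carries the gain, which the unsubstituted thiophen-2-yl group or 5-bromothiophen-2-yl would address. Nor do they show how this position responds to non-aromatic groups other than methylsulfanyl, such as an amine, a morpholine ring or a longer thioether chain.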